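Ethoxy to cyclopropylmethoxy: solubility notes

The source may hold more compounds than are shown below. What is called first, only, known or untested is meant among the compounds shown, and "the series" means these compounds.

Measured in a physicochemical assay for solubility, measured as thermodynamic solubility, at pH 7.4; a lower number here means a less soluble compound, a higher number a more soluble compound:
- compound 1 `CCOc1cc2[nH]c(Cc3nn(CC(=O)O)c(=O)c4ccccc34)nc2cc1Cl`: 917 ug/mL
- compound 2 `O=C(O)Cn1nc(Cc2cn3cc(OCC4CC4)c(Cl)cc3n2)c2ccccc2c1=O`: > 1000 ug/mL, a limit of the assay

For the measured compounds named here, compound 1 holds the only exact number so far, 917 ug/mL. The one other result, that of compound 2, is a limit. Compound 3 `O=C(O)Cn1nc(Cc2nc3cc(Cl)c(OCC4CC4)cc3[nH]2)c2ccccc2c1=O` is not yet measured. It differs from compound 1 by cyclopropyl in place of methyl on a saturated chain carbon bound to an oxygen on an aromatic ring, ethoxy to cyclopropylmethoxy (cyclopropyl in place of methyl on a saturated chain carbon bound to an oxygen on an aromatic ring). Going by the values given here, no measured step isolates this change. Compound 2 also carries cyclopropylmethoxy, on another core, and its result is only a limit. In this assay, a slight downward drift is expected, with no step beyond the scatter. The estimated step is a 1.3-fold lower number from compound 1 to compound 3 (0.12 log units; within the scatter). For compound 3 the expected value is 700 ug/mL, with an estimated range of 300 ug/mL to 1000 ug/mL.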

Compound 3, solubility: 395 ug/mL
The estimate for compound 3 lay 1.8-fold (0.25 log units) above the measured number; low and high end bracket the measured number.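

In this assay, for the compounds shown here, the pair gives the first readable step at this position: cyclopropyl in place of methyl on a saturated chain carbon bound to an oxygen on an aromatic ring, ethoxy to cyclopropylmethoxy, gives a 2.3-fold lower number from compound 1 to compound 3 (0.37 log units; beyond the scatter). The position therefore responds to this change on the shared core, by a modest step beyond the scatter. Steps involving compound 2 cannot be read, because its result is a limit of the assay: the limit of > 1000 ug/mL in this assay, at which 1 of the 3 values shown sits.

From the compounds shown here alone, the series offers a single pair for this change, so it remains open whether the step is specific to cyclopropyl or would also appear with a longer chain such as propoxy or butoxy. Also open, going by these compounds, is how an amine on the same chain would read, and whether the step carries over to another core.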